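Cyclobutyl to 4-fluoropiperidin-1-yl on the carbonyl carbon

This account rests on a few compounds, and the source may have more. Where it says the series, first, only, none or still open, it means among the compounds named here.

Working notes on the series. Compound 1, `O=C(C1CCC1)N1CCc2nc(C#Cc3ccccc3)sc2C1`, has been run in an assay on HEK293 cells for positive allosteric modulation of metabotropic glutamate receptor 5 (Homo sapiens), read by FLIPR, with a stated time of 1 h; a lower number here means that less compound is needed, a higher number that more compound is needed for the effect. In this assay compound 1 gives > 10000 nM, which is a limit of the assay and not a number. Compound 1 therefore stands at the limit of > 10000 nM in this assay, at which 1 of the 2 values shown sits. Compound 2, `O=S(=O)(N1CCCCC1)N1Cc2nc(C#Cc3ccccc3)sc2C1`, gives 250 nM in this assay. For the measured compounds named here, the two values show a bounded reading for compound 1 and a number for compound 2, and no single-point step between compound 1 and compound 2 is defined.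

Compound 3, `O=C(N1CCC(F)CC1)N1CCc2nc(C#Cc3ccccc3)sc2C1`, is not yet measured in this assay. It differs from compound 1 in one place: 4-fluoropiperidin-1-yl in place of cyclobutyl on a carbonyl carbon. The four-membered ring of carbon only leaves and a six-membered non-aromatic ring with one hetero atom enters on the carbonyl carbon.

Going by the values given here, no measured step sets the expected size of this change. The step of an at least 3.3-fold lower number from compound 1 to compound 3 (0.52 log units; beyond the scatter) is expected to be toward a lower number, of moderate size and beyond the usual scatter, though compound 1 offers only a limit as a starting point. Compound 3 is estimated at 3000 nM in this assay, with an expected range from 500 nM to 20000 nM.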

Compound 3, half-maximal effective concentration: 74 nM
The estimate for compound 3 lay 41-fold (1.61 log units) above the measured number; measured number outside the range, below it.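

For the compounds shown here, on the carbonyl carbon whose other neighbour is the amide-type ring nitrogen of the shared core, the group carried there matters greatly in this assay: 4-fluoropiperidin-1-yl in place of cyclobutyl gives an at least 130-fold lower number from compound 1 to compound 3 (2.13 log units; beyond the scatter), a large step and the first single-place change. The position therefore admits a six-membered non-aromatic ring with one hetero atom, and in this assay compound 3 gives 74 nM with that group in place. The true size of the step stays unknown, and the printed figure is only a lower bound, since the starting point for the change is a limit of the assay and not a number: the limit of > 10000 nM in this assay, at which 1 of the 3 values shown sits.

This one step changes ring size, the ring hetero atom and the fluorine together, so the compounds shown do not say which of these goes with the lower number. Unsubstituted piperidin-1-yl would separate the fluorine from the ring, cyclohexyl would separate the ring nitrogen from the ring size, and morpholin-4-yl or pyrrolidin-1-yl would show how far this position accepts other rings on the carbonyl carbon.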